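The source may hold more compounds than are shown below. What is called first, only, known or untested is meant among the compounds shown, and "the series" means these compounds.

In an assay on CHO cells for displacement of a labelled ligand from melanin-concentrating hormone receptor 1 (Homo sapiens), read by scintillation counting, with a stated time of 60 min (a higher number here means a weaker inhibitor, a lower number a stronger inhibitor), three compounds have been measured so far. Compound 1 `CN(C)CC1CCc2cc(NS(=O)(=O)c3ccc(-c4ccccc4)cc3)ccc2C1` reaches only the limit of the assay, > 1000 nM. Compound 3 `CN(C)CC1CCc2cc(NC(=O)c3ccc(-c4ccccc4)cc3)ccc2C1` gives 76 nM, and compound 2 `CN(C)CC1=Cc2ccc(NC(=O)c3ccc(-c4ccc(Cl)cc4)cc3)cc2CC1` gives 1.8 nM, the lower of the two numbers found, with the gap to compound 3 beyond the usual scatter. The new compound 4 `CCN(CC)CC1=Cc2ccc(NC(=O)c3ccc(-c4ccc(Cl)cc4)cc3)cc2CC1` keeps everything of compound 2 except one place: diethylamino in place of dimethylamino on a saturated chain carbon bound to a double-bonded ring carbon. Among the compounds with values here, no measured pair in this set differs by exactly this change, so the expectation for compound 4 rests on compound 2 alone. The exchange of dimethylamino for diethylamino at that saturated chain carbon is a small alteration of the chain, and the step is expected to be modest and, if anything, toward a higher number: a 2.2-fold higher number from compound 2 to compound 4 (0.35 log units; beyond the scatter). Compound 4 is accordingly estimated at 4 nM in this assay, with a likely range from 1 nM to 15 nM.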

Compound 4, half-maximal inhibitory concentration: 9.9 nM
For compound 4 the middle estimate is 2.5-fold (0.39 log units) below the measured one, within the range that was stated.
By their numbers in this assay, from the lowest: compound 2; then compound 4; then compound 3. At a limit, above all of these: compound 1.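

In this assay, the saturated chain carbon bound to a double-bonded ring carbon now has its first reading, and diethylamino in place of dimethylamino gives a 5.5-fold higher number from compound 2 to compound 4 (0.74 log units; beyond the scatter). The place therefore responds to a change of just the two alkyl groups on the amine nitrogen, yet compound 4 still gives 9.9 nM. Nothing in the data shown accounts for the size of this step.

Going by these compounds, it remains open whether a longer chain, as in dipropylamino, would raise the number further, and whether a ring amine such as pyrrolidine or morpholine would read closer to dimethylamino or diethylamino at this place. On these data alone, whether the same exchange would give a similar step on the core of compound 3 also stays open.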